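The source may report more compounds than this note shows. Statements on the series, on what has been measured and on what is new or still open speak of the compounds shown alone.

Compound 1 `CC(C)(C)c1ccc(C(=O)N2CCC3(CC2)C(=O)N(CC(=O)NCNS(C)(=O)=O)CN3c2ccccc2)cc1` was tested in an assay on HEK293 cells for displacement of a labelled ligand from NPC1-like intracellular cholesterol transporter 1 (Homo sapiens) (a higher number here means a weaker inhibitor, a lower number a stronger inhibitor), and gives 3200 nM. Going by these compounds, compound 2 `COC(=O)CCCNC(=O)CN1CN(c2ccccc2)C2(CCN(C(=O)c3ccc(C(C)(C)C)cc3)CC2)C1=O` shares the same core, but in this assay compound 2 gives "not determined" (no result reported), so its standing on the numbers is unknown. Compound 3 `CC(C)(C)c1ccc(C(=O)N2CCC3(CC2)C(=O)N(CC(=O)NCCCNS(C)(=O)=O)CN3c2ccccc2)cc1` differs from compound 2 by methanesulfonamido in place of methoxycarbonyl on a saturated chain carbon, three bonds along the chain from an amide-type nitrogen. Within the data shown here, with no measured step between these compounds, the size of any shift in this assay is open, and the only anchor is the value of compound 1. Compound 3 is expected to come in near 3000 nM, within a range of 800 nM to 12000 nM.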

Compound 3, half-maximal inhibitory concentration: 10400 nM
Beside the measured number, compound 3's estimate is 3.5-fold (0.54 log units) below it; measured number inside the range.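

In this assay, among these compounds, 2-(methanesulfonamido)ethyl in place of methanesulfonamido gives a 3.3-fold higher number from compound 1 to compound 3 (0.51 log units; beyond the scatter) and is the first measured step at this position, showing that the read-out responds to a change in this chain and that the longer chain here goes with a weaker inhibitor. No measured evidence accounts for this step. The comparison of methanesulfonamido with methoxycarbonyl cannot be read, as compound 2 has no value. Going by these compounds, whether a longer chain would continue this trend, or a carboxylic acid at the chain end would alter it, remains open.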